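This account rests on a few compounds, and the source may have more. Where it says the series, first, only, none or still open, it means among the compounds named here.

Series notes. In an ADME assay on RAW264.7 cells (Mus musculus) for cytotoxicity, read by MTT assay, with a stated time of 24 h, in the absence of a further agent (on this read-out lower numbers stand for stronger inhibition and higher numbers for weaker inhibition), compound 1 `O=C1OC(Cc2nc(Cc3ccccc3)no2)c2ccccc21` gives only a limit of the assay, > 40000 nM. Compound 2 `O=C1OC(Cc2nc(-c3ccc(Oc4ccccc4)cc3)no2)c2ccccc21` likewise reaches only a limit in this assay, > 40000 nM. Compound 3 `CCCCOc1ccc(C(O)C2OC(=O)c3c(OC)cc(OC)cc32)cc1` also stands at a limit in this assay, > 40000 nM, so no number is known for it; all three values shown sit at the limit of > 40000 nM in this assay, at which 3 of the 3 values shown sit. Compound 4 `COc1cc(OC)c2c(c1)C(C(O)c1ccc(OCc3ccccc3)cc1)OC2=O` differs from compound 3 by phenyl in place of propyl on a saturated chain carbon bound to an oxygen on an aromatic ring. Among the compounds with values here, no step between measured compounds is available, so the change is expected to bring no shift beyond the scatter, and the step is estimated as a step that the limit leaves unreadable from compound 3 to compound 4. Compound 4 is expected at 60000 nM, within a range of 30000 nM to 150000 nM, most likely reported again only as a limit in this assay.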

Compound 4, half-maximal inhibitory concentration: > 40000 nM
Compound 4: only a limit was reported (the forecaster's own chance of this, stated with the estimate: 80%); the middle value is on the limit's open side.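

No step can be read from compound 3 to compound 4, since both values are only limits: the limit of > 40000 nM in this assay, at which 4 of the 4 values shown sit. The compounds shown leave open whether phenyl in place of propyl changes anything in this assay, and where any true value lies.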